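This account rests on a few compounds, and the source may have more. Where it says the series, first, only, none or still open, it means among the compounds named here.

Working notes on the sulfonamide series.

Compound 1 `O=C(NCc1ccc(C(F)(F)F)cc1)c1ccc(S(=O)(=O)Nc2nccs2)cc1` is measured in an assay on cells for inhibition of sodium channel protein type 3 subunit alpha (Homo sapiens), read by electrophysiology (a higher number here means a weaker inhibitor, a lower number a stronger inhibitor), at 147 nM. Compound 3 `O=S(=O)(CCc1ccc(C(F)(F)F)cc1)c1ccc(S(=O)(=O)Nc2nccs2)cc1` gives 155 nM in this assay, and the two numbers sit within the scatter of each other, so no order between compound 1 and compound 3 is claimed. Compound 2 `O=C(COc1ccc(F)cc1)N1CCc2cc(S(=O)(=O)Nc3nccs3)ccc21`, which carries a different core, gives 2510 nM in this assay; its number stands well beyond the scatter from that of compound 1. Compound 1 thus holds the lowest of the three numbers, equal within scatter to compound 3 and clearly separated from compound 2 only.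

Compound 4 `O=C(NCc1ccc(OC(F)(F)F)cc1)c1ccc(S(=O)(=O)Nc2nccs2)cc1` is the next entry and differs from compound 1 in one place: trifluoromethoxy in place of trifluoromethyl on an aromatic carbon. Among the compounds with values here, no measured pair in this set shows the same change, so the size of its effect has to be guessed from the structures alone. The change keeps the amide linker and the shared core of compound 1 intact and exchanges one small non-ionised group for another of similar bulk at the same position on the outer ring. The expected step from compound 1 to compound 4 is therefore small, a 1.2-fold higher number from compound 1 to compound 4 (0.09 log units; within the scatter), and not clearly beyond the scatter in either direction. Compound 4 is estimated at 180 nM in this assay, with a plausible range from 60 nM to 550 nM.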

Compound 4, half-maximal inhibitory concentration in the sodium channel protein type 3 subunit alpha assay: 197 nM
For compound 4 the middle estimate is 1.1-fold (0.04 log units) below the measured one; measured number inside the range.
By their numbers in the sodium channel protein type 3 subunit alpha assay, from the lowest: compounds 1, 3 and 4 (each within the scatter of the next); then compound 2.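

Within the data shown here, the change from trifluoromethyl to trifluoromethoxy on an aromatic carbon, para to a large group, gives in the sodium channel protein type 3 subunit alpha assay a 1.3-fold higher number from compound 1 to compound 4 (0.13 log units; within the scatter), the first single-place step, with compound 1 at 147 nM and compound 4 at 197 nM. This position on the outer ring therefore takes trifluoromethoxy, with its added oxygen and hydrogen-bond acceptor, with no step beyond the scatter in this assay. In a physicochemical assay for lipophilicity (a higher number here means a more lipophilic compound, a lower number a more polar compound), compound 1 gives 2.5 and compound 4 gives 2.6, and the same change gives a number 0.10 log units higher from compound 1 to compound 4 (within the scatter), so neither read-out separates the two groups, and nothing in hand offers a reason for either step.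

What the compounds shown leave open is how this position responds to a group of a different kind, such as an amine or a carboxylic acid, or to a longer chain in place of trifluoromethyl. Also open is whether the same exchange would give a step of similar size on the linker of compound 3, since the one pair shown carries the amide linker of compound 1.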